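Shifting a Methoxy Group: Compound 1 to Compound 4

A few compounds are considered here, and "the series" means these few. Any claim that something is new, unique, unknown or untested is made for them only; others in the source may bear on it.

Compound 1 `COc1ccccc1/C=C/C(=O)OC/C=C/c1cc(OC)c(OC)cc1OC` is one of three esters that have been measured in a functional assay on the whole organism (strain Kunming) with Mus musculus as the target, with a stated time of 0.5 h, at a dose of 300 mg/kg by the intraperitoneal route (on this read-out lower numbers stand for a stronger effect and higher numbers for a weaker effect at the one dose given), where compound 1 gives 100%. Compound 2 `COc1cccc(/C=C/C(=O)OC/C=C/c2cc(OC)c(OC)cc2OC)c1` gives 100% in this assay, and compound 3 `COc1cc(OC)c(OC)cc1/C=C/COC(=O)/C=C/c1cc(OC)c(OC)c(OC)c1OC` gives 100%. On these numbers compound 1 stands level with compound 2 and compound 3 at the digits shown; none of the three can be told apart from another, since the read-out sits at the same figure for all of them.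

Compound 4 `COc1ccc(/C=C/C(=O)OC/C=C/c2cc(OC)c(OC)cc2OC)cc1` has not yet been measured. It differs from compound 1 in one place: 4-methoxyphenyl in place of 2-methoxyphenyl on a double-bonded chain carbon bound to a double-bonded chain carbon. Among the measured compounds shown here, the only measured step that bears on this kind of change is the one from compound 1 to compound 2, in which a 3-methoxyphenyl replaced the 2-methoxyphenyl, and that step was no change at the digits printed from compound 1 to compound 2 (within the scatter). Since the two methoxyphenyl groups measured so far leave the read-out at the same figure, and compound 3 with its different substitution also sits at 100%, there is no sign within this small set that the methoxyphenyl group chosen changes the outcome at this dose. Compound 4 is therefore expected to show no step beyond the scatter, no change at the digits printed from compound 1 to compound 4 (within the scatter). The read-out of compound 4 in this assay is estimated at 100%, within a range from 85% to 100%.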

Compound 4, a percentage reported as activity, at one dose (the size of the read-out at that dose, not a potency): 100%
Compound 4: middle estimate and measured number agree at the digits printed, within the range that was stated.
By their numbers in this assay, from the lowest: compounds 1, 2, 3 and 4 (each within the scatter of the next).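

In this assay, the 4-methoxyphenyl group on a double-bonded chain carbon bound to a double-bonded chain carbon gives no change at the digits printed from compound 1 to compound 4 (within the scatter) and no change at the digits printed from compound 2 to compound 4 (within the scatter) in this read-out. Before this result, only the 2-methoxyphenyl and 3-methoxyphenyl groups had been compared at this place; with the 4-methoxyphenyl group added, moving the methoxy group around this phenyl ring does not separate compound 1, compound 2 and compound 4 at the one dose given. Nothing at hand offers an explanation for this flat result.

Among the compounds shown here, since these three compounds share a single figure, the set does not show whether any group at this place can lower the read-out, and a methoxy group moved around the phenyl ring is the only change it covers here. It leaves open whether an amine, a carboxylic acid or a longer chain in place of the methoxy group would give a number that differs from those of compound 1, compound 2 and compound 4.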